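Notes on swapping dimethylamino for isopropoxy

The compounds below may be only part of what the source reports. "The series", "measured", "known", "first", "only" and "open" are said of these compounds alone.

Values in a functional assay on MV4-11 cells (Homo sapiens) for inhibition, read by resazurin assay, with a stated time of 72 h; a lower number here means a stronger inhibitor of growth, a higher number a weaker inhibitor of growth:
- compound 1 `COCCSc1nc(C)c(-c2ccnc(Nc3ccc(OC)cc3OC)n2)s1`: 810 nM
- compound 2 `CNc1nc(C)c(-c2ccnc(Nc3ccc(OC)cc3OC)n2)s1`: 300 nM
- compound 3 `COc1ccc(Nc2nccc(-c3sc(N(C)C)nc3C)n2)c(OC)c1`: 170 nM

Compound 3 stands at the low end of these numbers, with the closest neighbour inside the scatter: a 1.8-fold lower number from compound 2 to compound 3 (0.25 log units; within the scatter). Compound 4 `COc1ccc(Nc2nccc(-c3sc(OC(C)C)nc3C)n2)c(OC)c1` carries isopropoxy in place of dimethylamino on an aromatic carbon. Among the compounds with values here, no measured step makes this exact change. The nearest evidence is the replacement of (2-methoxyethyl)sulfanyl by the two amino groups: a 2.7-fold lower number from compound 1 to compound 2 (0.43 log units; beyond the scatter) and a 4.8-fold lower number from compound 1 to compound 3 (0.68 log units; beyond the scatter). Leaving dimethylamino for a group without nitrogen may partly reverse these steps, so a modest rise is expected in this assay. The expected step is a 2.4-fold higher number from compound 3 to compound 4 (0.37 log units; beyond the scatter). Compound 4 is estimated at 400 nM, with a range of 150 nM to 1000 nM.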

Compound 4, concentration for 50% growth inhibition: 8690 nM
Beside the measured number, compound 4's estimate is 22-fold (1.34 log units) below it; the measured number lies above the stated range.
By their numbers in this assay, from the lowest: compounds 3 and 2 (each within the scatter of the next); then compound 1; then compound 4.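

In this assay, isopropoxy on this aromatic carbon of the five-membered ring gives a far higher number than either amino group (a 51-fold higher number from compound 3 to compound 4 (1.71 log units; beyond the scatter) and a 29-fold higher number from compound 2 to compound 4 (1.46 log units; beyond the scatter)). It also stands well above the sulfur-linked (2-methoxyethyl)sulfanyl group (an 11-fold higher number from compound 1 to compound 4 (1.03 log units; beyond the scatter)), so the oxygen-linked group gives the highest number of the four groups compared at this position. Nothing shown accounts for the size of these steps. As far as these compounds go, whether a cyclic amine such as morpholine would stay near the amino compounds remains open. So does whether a smaller methoxy group would share the high number of isopropoxy.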